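From hydroxy to piperidinyl on a receptor binder

The compounds below may be only part of what the source reports. "The series", "measured", "known", "first", "only" and "open" are said of these compounds alone.

Three compounds have been measured in an assay on isolated protein for binding affinity to melanin-concentrating hormone receptor 1 (Homo sapiens); on this read-out higher numbers stand for weaker inhibition and lower numbers for stronger inhibition:
compound 1 `CN1CCN(CCCN(c2nc3cc(F)c(C(F)(F)F)cc3[nH]2)[C@@H]2CC[C@]3(c4ccc(C#N)cc4)C[C@H]23)CC1` gives 8.6 nM;
compound 2 `CS(=O)(=O)N1CCC(CN(c2nc3cc(F)c(F)cc3[nH]2)[C@@H]2CC[C@]3(c4cccc(C#N)c4)C[C@@H]3C2)CC1` gives 27 nM;
compound 3 `CN1CCN(CCCN(c2nc3cc(F)c(F)cc3[nH]2)[C@@H]2CC[C@]3(c4cccc(CO)c4)C[C@@H]3C2)CC1` gives 70.8 nM.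

Compound 3 has the highest number of the three, and both gaps lie beyond the scatter: compound 2 is nearest, compound 1 furthest, so compound 3 is the weakest binder shown. Compound 4 `CN1CCN(CCCN(c2nc3cc(F)c(F)cc3[nH]2)[C@@H]2CC[C@]3(c4cccc(CN5CCCCC5)c4)C[C@@H]3C2)CC1` keeps the rest of compound 3 but carries piperidin-1-yl in place of hydroxy on a saturated chain carbon bound to an aromatic carbon. Going by the values given here, no measured pair differs in only one place, so there is no directly comparable step to lean on, and a piperidinylmethyl group is new to this set. A modest move toward a lower number is expected, of a size near the edge of the scatter. Compound 4 is therefore estimated at 30 nM, within a range from 8 nM to 120 nM. The expected step is a 2.4-fold lower number from compound 3 to compound 4 (0.37 log units; beyond the scatter).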

Compound 4, inhibition constant: 405 nM
Estimate against measurement, compound 4: 14-fold (1.13 log units) below; measured number outside the range, above it.
By their numbers in this assay, from the lowest: compound 1; then compound 2; then compound 3; then compound 4.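

In this assay, going by these compounds alone, this is the first comparison in the set that changes only one place: piperidin-1-yl in place of hydroxy gives a 5.7-fold higher number from compound 3 to compound 4 (0.76 log units; beyond the scatter), meaning weaker inhibition. Binding therefore depends on what sits on this saturated chain carbon, and this larger ring group is not an improvement over hydroxy here. Nothing available explains the drop. This single change adds a ring and removes a hydrogen-bond donor together, so their contributions cannot be separated. From the compounds shown here alone, how a small dimethylamino group or a carboxylic acid would fare on the same carbon remains open.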